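Removing the carboxy group on the chain of compound 2

The source may hold more compounds than are shown below. What is called first, only, known or untested is meant among the compounds shown, and "the series" means these compounds.

Among the measured compounds shown here, compound 2, with the structure `CCCn1c(=O)n(CC(=O)O)c(=O)c2[nH]cnc21`, stands highest of the two numbers measured so far in a functional assay (trachea) with Cavia porcellus as the target; on this read-out higher numbers stand for an effect only at larger amounts of compound and lower numbers for an effect already at smaller amounts: compound 2 gives 41000 nM. Its nearest neighbour is compound 1, with the structure `CCCn1c(=O)n(CC)c(=O)c2[nH]cnc21`, which in this assay gives 1300 nM. For the measured compounds named here, the only measured step connects these two, and it is large: a 32-fold higher number from compound 1 to compound 2 (1.50 log units; beyond the scatter), the change being carboxy in place of methyl on a saturated chain carbon bound to an aromatic nitrogen.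

Compound 3, with the structure `CCCn1c(=O)n(CCC(C)=O)c(=O)c2[nH]cnc21`, has not yet been measured. It differs from compound 2 in one place: 2-oxopropyl in place of carboxy on a saturated chain carbon bound to an aromatic nitrogen. The step from compound 1 to compound 2 bears on this, since it shows what the carboxy group cost on this read-out, and the change to compound 3 takes that carboxy group away again. A drop in the number is therefore expected, of a size a 14-fold lower number from compound 2 to compound 3 (1.14 log units; beyond the scatter), back toward the level of compound 1. For compound 3 the expected value in this assay is estimated at 3000 nM, with a range from 800 nM to 12000 nM.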

Compound 3, half-maximal effective concentration: 3500 nM
Compound 3: middle estimate off by 1.2-fold (0.07 log units), on the low side; low and high end bracket the measured number.
By their numbers in this assay, from the lowest: compound 1; then compound 3; then compound 2.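

In this assay, exchanging carboxy for 2-oxopropyl on a saturated chain carbon bound to an aromatic nitrogen gives a 12-fold lower number from compound 2 to compound 3 (1.07 log units; beyond the scatter), so most of the ground lost with carboxy is recovered while the chain grows longer and keeps a carbonyl. The recovery is only partial, as the comparison with the plain chain shows a 2.7-fold higher number from compound 1 to compound 3 (0.43 log units; beyond the scatter); among these three compounds, the acetyl-bearing chain carries a modest penalty, and the large one belongs to the carboxy group of compound 2. Which feature of the two groups sets this difference cannot be told, although the count shows that carboxy has a hydrogen-bond donor and 2-oxopropyl has none, and no supporting measurement bears on the matter.

The compounds shown leave open whether the carbonyl of compound 3 matters at all, which a plain butyl chain at this place would test against the values of compound 1 and compound 3. They also leave open how a hydroxyl, a primary amide or a methyl ester on this chain would read in this assay, and so how closely the large penalty is tied to the carboxylic acid itself.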